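The source may hold more compounds than are shown below. What is called first, only, known or untested is meant among the compounds shown, and "the series" means these compounds.

Working notes on the series. Three compounds have numbers in an assay on mitochondria from L6 cells (Rattus norvegicus) for activation, with a stated time of 90 min; a higher number here means that more compound is needed for the effect, a lower number that less compound is needed. Compound 1, `COc1cc(OC(F)(F)F)ccc1Nc1nc2nonc2nc1O`, gives 3800 nM in this assay. Compound 2, `CCCCOc1ccc(Nc2nc3nonc3nc2O)cc1`, gives 3700 nM in this assay. Compound 3, `Oc1nc2nonc2nc1Nc1ccc(OCC2CC2)c(C(F)(F)F)c1`, gives 1800 nM in this assay. Among these, compound 2 stands second highest of the three numbers; compound 1 sits within the scatter of it, so nothing separates the two, while compound 3 gives a lower number, and that gap lies beyond the scatter.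

Compound 4, `Oc1nc2nonc2nc1Nc1ccc(OCc2ccccc2)cc1`, has not yet been measured in this assay. The change from compound 2 is phenyl in place of propyl on a saturated chain carbon bound to an oxygen on an aromatic ring. Going by the values given here, no pair of measured compounds shows this change on its own, so its effect here is not known from the numbers at hand. The only measured variation at the ether carbon is the cyclopropylmethoxy of compound 3, which carries a further difference and so cannot be read as a clean step.

The expectation for compound 4 is therefore a step of a 1.5-fold lower number from compound 2 to compound 4 (0.17 log units; within the scatter) in this assay, a small lowering of the number or none beyond the scatter. The estimated value for compound 4 is 2500 nM, with a range from 900 nM to 7000 nM.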

Compound 4, half-maximal effective concentration: 2400 nM
For compound 4 the middle estimate is 1.0-fold (0.02 log units) above the measured one; the range from low to high includes it.
By their numbers in this assay, from the lowest: compounds 3, 4, 2 and 1 (each within the scatter of the next, the first and the last beyond it).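

In this assay, phenyl in place of propyl on a saturated chain carbon bound to an oxygen on an aromatic ring, which also reads as butoxy to benzyloxy, gives a 1.5-fold lower number from compound 2 to compound 4 (0.19 log units; within the scatter). Going by these compounds alone, this is the first step that can be read at this position on its own, and it shows that an open chain can give way to a six-membered aromatic ring of carbon only, with more heavy atoms, while the number stays within the scatter. The step therefore gives no sign that this change either helps or harms in this assay, and no measurement at hand bears on why that is so.

What lies open is how far this position stays this flat: an amine or a carboxylic acid at the end of the chain, a longer chain such as hexyl, or a nitrile on the incoming phenyl could each move the number differently. The compounds shown also leave open whether the same change gives a similarly small step on the other aromatic substitution patterns in the series.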